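Swapping a hydroxy for an amino on compound 1

This account rests on a few compounds, and the source may have more. Where it says the series, first, only, none or still open, it means among the compounds named here.

Compound 1 `CCn1ccc(N2C[C@H](CO)OC2=O)c1` is the reference point here. In an assay for inhibition of Amine oxidase [flavin-containing] B (Bos taurus), read by fluorescence, with a stated time of 30 min (on this read-out lower numbers stand for stronger inhibition and higher numbers for weaker inhibition), compound 1 gives 300 nM, the lowest number among the three compounds measured. Its closest neighbour is compound 3 `C=CCn1ccc(N2C[C@H](COC)OC2=O)c1`, which gives 200000 nM, and the furthest is compound 2 `C=CCn1ccc(N2C[C@H](CO)OC2=O)c1`, which gives 625000 nM. The move from compound 1 to compound 2 was a single change, vinyl in place of methyl on the chain carbon bound to the aromatic nitrogen, and it gave a 2100-fold higher number from compound 1 to compound 2 (3.32 log units; beyond the scatter). The move from compound 2 to compound 3, methyl in place of hydrogen on the oxygen, gave a 3.1-fold lower number from compound 2 to compound 3 (0.49 log units; beyond the scatter).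

The compound now in question, compound 4 `CCn1ccc(N2C[C@H](CN)OC2=O)c1`, differs from compound 1 by amino in place of hydroxy on a saturated chain carbon bound to a saturated ring carbon. Neither measured step touches this exact change. The step from compound 2 to compound 3 is the only one that alters the hydroxy group at all, and it was modest, so a modest move is the most that can be drawn from the data; the direction is open. Compound 4 is therefore expected to show a 5.0-fold higher number from compound 1 to compound 4 (0.70 log units; beyond the scatter), landing at an estimated 1500 nM in this assay, within a range of roughly 150 nM to 20000 nM.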

Compound 4, inhibition constant: 25000 nM
Compound 4: middle estimate off by 17-fold (1.22 log units), on the low side; measured number above the stated range.
By their numbers in this assay, from the lowest: compound 1; then compound 4; then compound 3; then compound 2.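

In this assay, the hydroxymethyl to aminomethyl swap gives an 83-fold higher number from compound 1 to compound 4 (1.92 log units; beyond the scatter), so this place on the core of compound 1 responds strongly to a change of a single atom. Among these compounds, the only earlier change at this hydroxy group, methyl in place of hydrogen on the oxygen, gave just a 3.1-fold lower number from compound 2 to compound 3 (0.49 log units; beyond the scatter), and that step was read on a compound already carrying the vinyl change, so it gave no sign that a swap here could be this large. The two groups match in their computed counts of heavy atoms, hydrogen-bond donors and hydrogen-bond acceptors and in net charge, so those counts alone do not separate a compound that stays at the low end of the series from one with a much higher number.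

No available evidence explains the size of this step. The compounds shown also leave open how other groups would fare at this place on the core of compound 1, such as a dimethylamino group, a fluorine or a longer chain ending in an amine, and so whether the hydroxy group is uniquely favoured or the amino group uniquely poor.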